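The source may report more compounds than this note shows. Statements on the series, on what has been measured and on what is new or still open speak of the compounds shown alone.

Among the measured compounds shown here, in an ADME assay on HEL cells (Homo sapiens) for cytotoxicity (a lower number here means that less compound is tolerated, a higher number that more compound is tolerated), compound 2 `C/C(=N\NC(=O)COc1cccc2ccccc12)c1ccc(C#N)cc1Br` gives 20 ug/mL, the lowest of the three numbers measured so far. Compound 1 `O=C(COc1cccc2ccccc12)N/N=C/c1cccc(O)c1` gives 100 ug/mL in this assay, and compound 3 `O=C(COc1cccc2ccccc12)N/N=C/c1ccccc1` gives 100 ug/mL; the step of no change at the digits printed from compound 1 to compound 3 (within the scatter) stays within the scatter. Compound 4 `C/C(=N\NC(=O)COc1cccc2ccccc12)c1ccc(Br)cc1` has not yet been measured in this assay. It differs from compound 2 in one place: 4-bromophenyl in place of 2-bromo-4-cyanophenyl on a carbon with a double bond to nitrogen. For the measured compounds named here, no measured pair shows this change. Going by the values given here, the only measured step, hydrogen in place of hydroxy on an aromatic carbon, concerns a different part of the molecule, and compounds 1 and 3 differ from compounds 2 and 4 in further places as well, so there is no direct precedent. The higher numbers of compound 1 and compound 3 suggest that the shared core is tolerated at higher concentrations, so the expected move is small and toward a higher number, a 2.0-fold higher number from compound 2 to compound 4 (0.30 log units; within the scatter). Compound 4 is therefore expected to give about 40 ug/mL, with a range from 15 ug/mL to 100 ug/mL.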

Compound 4, minimum cytotoxic concentration: 20 ug/mL
Beside the measured number, compound 4's estimate is 2.0-fold (0.30 log units) above it, and the stated range covers the measured number.
By their numbers in this assay, from the lowest: compounds 2 and 4 (each within the scatter of the next); then compounds 1 and 3 (each within the scatter of the next).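

In this assay, putting 4-bromophenyl in place of 2-bromo-4-cyanophenyl on a carbon with a double bond to nitrogen gives no change at the digits printed from compound 2 to compound 4 (within the scatter). Among the compounds shown here, this is the first measured change at this position, as the earlier step concerned only a hydroxy group on an aromatic carbon, and for this pair the nitrile-bearing group and the simpler 4-bromophenyl group cannot be told apart in this assay. No measured information explains why the two compounds match.

As far as these compounds go, it remains open whether a quite different group on this carbon, such as a phenyl ring carrying an amine or a carboxylic acid, would move the number beyond the scatter. The compounds shown also leave open what a longer chain in place of the ring would do.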